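From Naphthyl to Dichlorophenyl on a Shared Core

The compounds below may be only part of what the source reports. "The series", "measured", "known", "first", "only" and "open" are said of these compounds alone.

Compound 1 `COc1cc(N2C(N)=C(C#N)C(c3ccc(OC)c4ccccc34)C3=C2CC(C)(C)CC3=O)cc(OC)c1OC` was tested in a functional assay on Ehrlich cells (Mus musculus) for cytotoxicity, tested at 50 ug/mL (on this read-out lower numbers stand for a weaker effect and higher numbers for a stronger effect at the one concentration tested), where compound 1 gives 40%, the second highest of the three numbers measured. Compound 2 `COc1ccccc1C1C(C#N)=C(N)N(c2cc(OC)c(OC)c(OC)c2)C2=C1C(=O)CC(C)(C)C2` gives 70%, and compound 3 `COc1cc(N2C(N)=C(C#N)C(/C=C/c3ccccc3)C3=C2CC(C)(C)CC3=O)cc(OC)c1OC` gives 30%. Compound 4 `COc1cc(N2C(N)=C(C#N)C(c3ccc(Cl)cc3Cl)C3=C2CC(C)(C)CC3=O)cc(OC)c1OC` differs from compound 1 in one place: 2,4-dichlorophenyl in place of 4-methoxynaphthalen-1-yl on a saturated ring carbon. Two measured steps change the same position. One six-membered aromatic ring entering raised the number, as the step of a number 30 percentage points higher from compound 1 to compound 2 (beyond the scatter) shows, whereas a 2-phenylethenyl group entering gave a number 10 percentage points lower from compound 1 to compound 3 (within the scatter). With one six-membered aromatic ring again entering, a rise is expected for compound 4 because a number 30 percentage points higher from compound 1 to compound 2 (beyond the scatter) went that way, giving an expected step of a number 15 percentage points higher from compound 1 to compound 4 (beyond the scatter). Compound 4 is therefore estimated at 55%, with a range from 30% to 80%.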

Compound 4, a percentage reported as activity, at one concentration (the size of the read-out at that concentration, not a potency): 95%
Compound 4: the middle estimate sits 40 percentage points below what was measured; measured number outside the range, above it.
By their numbers in this assay, from the lowest: compounds 3 and 1 (each within the scatter of the next); then compound 2; then compound 4.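

In this assay compound 4 stands highest of the four, with a number 55 percentage points higher from compound 1 to compound 4 (beyond the scatter) and a number 65 percentage points higher from compound 3 to compound 4 (beyond the scatter) at this saturated ring carbon. Having one six-membered aromatic ring here does not settle the outcome: changing what that ring carries, from methoxy to two chlorines, still gave a number 25 percentage points higher from compound 2 to compound 4 (beyond the scatter) so the groups on the ring matter at this position.

Going by these compounds, whether a phenyl with a single chlorine or a pyridine ring would hold this number stays open. Nothing at hand explains the rise.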